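A few compounds are considered here, and "the series" means these few. Any claim that something is new, unique, unknown or untested is made for them only; others in the source may bear on it.

The two measured compounds share one core. Compound 1 `Cc1ccc(-c2nnc(SCCOc3ccc(/C=C4\SC(=O)NC4=O)cc3)[nH]2)cc1` gives 16.9% in a functional assay on the whole organism (plasma, strain Wistar) with Rattus norvegicus as the target, with a stated time of 15 days, at a dose of 3 mg/kg by the oral route (a higher number here means a stronger effect of the compound at the dose given, a lower number a weaker effect), and compound 2 `O=C1NC(=O)/C(=C/c2ccc(OCCSc3nnc(-c4ccc(Br)cc4)[nH]3)cc2)S1` gives 13.2% in the same this assay. On the numbers shown, compound 2 stands lowest of the two, with compound 1 nearest, though the gap between them, a number 3.7 percentage points lower from compound 1 to compound 2 (within the scatter), lies within the scatter. Compound 3 `COc1ccc(-c2nnc(SCCOc3ccc(/C=C4\SC(=O)NC4=O)cc3)[nH]2)cc1` has not yet been measured in this assay. It differs from compound 2 by methoxy in place of bromo on an aromatic carbon. For the measured compounds named here, the one measured step that bears on this change is the exchange on the same aromatic carbon, methyl to bromo, which gave a number 3.7 percentage points lower from compound 1 to compound 2 (within the scatter), a step within the scatter. On that basis no step beyond the scatter is expected for methoxy in place of bromo, and the estimated step is a number 1.8 percentage points higher from compound 2 to compound 3 (within the scatter). Compound 3 is expected to give about 15% in this assay, within a range from 4% to 27%.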

Compound 3, a percentage reported as activity, at one dose (the size of the read-out at that dose, not a potency): 41.3%
Estimate against measurement, compound 3: 26.3 percentage points below; measured number above the stated range.
By their numbers in this assay, from the lowest: compounds 2 and 1 (each within the scatter of the next); then compound 3.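

In this assay, methoxy in place of bromo on this aromatic carbon amounts to a number 28.1 percentage points higher from compound 2 to compound 3 (beyond the scatter), and methoxy in place of methyl amounts to a number 24.4 percentage points higher from compound 1 to compound 3 (beyond the scatter). The position can therefore shift the read-out beyond the scatter, which the exchange of methyl and bromo had not shown, and the change holds against both of those groups. The data offer no evidence that would explain why methoxy differs in this way from the other two groups.

From the compounds shown here alone, it remains open whether this effect is particular to methoxy or would extend to a hydroxy group, an ethoxy group or a dimethylamino group on the same carbon. Going by these compounds, the read-out also comes from a single dose, so how the gap between these compounds behaves at other doses stays unknown.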